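A few compounds are considered here, and "the series" means these few. Any claim that something is new, unique, unknown or untested is made for them only; others in the source may bear on it.

Two compounds from this set share one core and differ only in the outer aromatic ring. Compound 1 `COc1ccc(Nc2nnc(Nc3nc(-c4ccc(Cl)cc4)cs3)s2)cc1` carries a methoxy group on that ring and a chlorine on the opposite aryl piece, while compound 2 `Cc1ccccc1Nc1nnc(Nc2nc(-c3ccc(Br)cc3)cs2)s1` carries a methyl group there and a bromine instead. In a functional assay on the whole organism (strain albino) with Mus musculus as the target, with a stated time of 4 h (on this read-out lower numbers stand for an effect already at smaller amounts and higher numbers for an effect only at larger amounts of compound), compound 1 gives 300 mg/kg. In this assay compound 2 gives 300 mg/kg, level with compound 1 at the digits shown, so the two values lie within the usual scatter and no order between them can be read.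

Compound 3 `COc1ccccc1Nc1nnc(Nc2nc(-c3ccc(Br)cc3)cs2)s1` has not yet been measured. It keeps the bromine side of compound 2 and changes the other ring: methoxy in place of methyl on an aromatic carbon. The change is the same one that separates compound 1 from compound 2 on the methoxy-bearing ring, and there it went together with no visible shift. With only these two values to lean on, no step beyond the scatter is expected from compound 2 to compound 3. In this assay compound 3 is estimated at 300 mg/kg, with a range from 150 mg/kg to 600 mg/kg, which means an expected step of no change at the digits printed from compound 2 to compound 3 (within the scatter).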

Compound 3, minimum effective dose: 300 mg/kg
Compound 3: the middle estimate sits on the measured number at the digits printed; measured number inside the range.
By their numbers in this assay, from the lowest: compounds 1, 2 and 3 (each within the scatter of the next).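

Among the compounds shown here, the replacement of methyl by methoxy on an aromatic carbon, ortho to a large group, is the first change here that stands alone in one place, and in this assay it gives no change at the digits printed from compound 2 to compound 3 (within the scatter). Compound 1 and compound 2 differ in more than one place, so their matching values could not be tied to any single group, whereas this pair shows that the swap on its own, which adds one oxygen and one hydrogen-bond acceptor by count, brings no readable shift on this read-out at this position. Nothing at hand offers an explanation for this result.

As far as these compounds go, whether a clearly different group on this aromatic carbon, such as an amine, a carboxylic acid or a longer chain, would move the minimum effective dose beyond the scatter remains open. Also open is whether the methyl-to-methoxy swap would give the same result with chlorine in place of bromine on the other aryl piece, since the pair shown here carries bromine only.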